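Taking the allyl group off a weak inhibitor

The source may hold more compounds than are shown below. What is called first, only, known or untested is meant among the compounds shown, and "the series" means these compounds.

Of the compounds shown here, three built on a shared core have been tested in a functional assay for inhibition, with Homo sapiens as the target; a higher number here means a weaker inhibitor, a lower number a stronger inhibitor. Compound 1 `Cc1nc(C)n2c(S)nncc12` carries a bare sulfur and two methyl groups; in this assay compound 1 gives > 48000 nM, which is a limit of the assay rather than a number. Compound 2 `C=CCSc1nncc2cnc(C)n12` carries an allyl group on its sulfur; in this assay compound 2 gives 61000 nM. Compound 3 `C=CCSc1nncc2cnc(COC)n12` has a methoxy in place of a hydrogen on a saturated chain carbon bound to an aromatic carbon; in this assay compound 3 gives 79000 nM. The step of a 1.3-fold higher number from compound 2 to compound 3 (0.11 log units; within the scatter) is within the scatter, so compound 2 and compound 3 cannot be told apart, and compound 2 stands alongside compound 3 among the measured numbers, with compound 1 at a limit only.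

Compound 4 `Cc1ncc2cnnc(S)n12` is not yet measured. It differs from compound 2 by hydrogen in place of allyl on a sulfur. Among the compounds with values here, no measured step covers this change; the one step measured touches a different place. Compound 1, the other compound with a bare sulfur, sits at the limit of > 48000 nM in this assay, at which 1 of the 3 values shown sits. The expectation for compound 4 is therefore a step of a 1.2-fold higher number from compound 2 to compound 4 (0.09 log units; within the scatter) that stays within the scatter or drifts to a slightly weaker number. The estimate for compound 4 is 75000 nM, ranging from 30000 nM to 200000 nM.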

Compound 4, half-maximal inhibitory concentration: > 48000 nM
Compound 4 was reported as a limit; the forecaster's own chance of this, stated with the estimate: 50%; the middle value is on the limit's open side.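

In this assay compound 4 gives > 48000 nM, which is a limit and not a number. Neither the step from compound 2 to compound 4 nor the step from compound 1 to compound 4 can be read. The compounds shown leave open how much, if at all, replacing allyl with hydrogen on the sulfur changes inhibition, with limits recurring among the results: the limit of > 48000 nM in this assay, at which 2 of the 4 values shown sit.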